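This account rests on a few compounds, and the source may have more. Where it says the series, first, only, none or still open, it means among the compounds named here.

Working notes on the series. In a functional assay on Vero cells (Chlorocebus sabaeus) for inhibition (on this read-out lower numbers stand for stronger inhibition and higher numbers for weaker inhibition), compound 1 `COc1cc(/C=C/C(=O)c2cccc(NC(=O)c3ccc(Cl)cc3)c2)ccc1O` gives 3.82 ug/mL, compound 2 `COc1cc(/C=C/C(=O)c2cccc(NC(=O)c3ccc(Cl)cc3Cl)c2)ccc1O` gives 27.2 ug/mL and compound 3 `COc1cc(/C=C/C(=O)c2cccc(NC(=O)C(C)C)c2)ccc1O` gives 3.47 ug/mL. Compound 2 therefore has the highest number of the three and is the weakest inhibitor, with both other compounds beyond the scatter from it.

Compound 4 `COc1cc(/C=C/C(=O)c2cccc(NC(=O)c3ccccc3)c2)ccc1O` differs from compound 2 by phenyl in place of 2,4-dichlorophenyl on a carbonyl carbon.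

For the measured compounds named here, three measured steps bear on this change. The closest is a 7.1-fold higher number from compound 1 to compound 2 (0.85 log units; beyond the scatter), where chloro replaces hydrogen on an aromatic carbon. Going by the values given here, compound 4 lacks that chloro and also the one carried by compound 1, and no measured pair shows the loss of that second chloro alone. Replacing the 2,4-dichlorophenyl with isopropyl gives a 7.8-fold lower number from compound 2 to compound 3 (0.89 log units; beyond the scatter), a step of similar size in the same direction. By contrast, a 1.1-fold lower number from compound 1 to compound 3 (0.04 log units; within the scatter) stays within the scatter.

A modest step towards a lower number is therefore expected in this assay, of about the size of those two steps. The expected change is a 6.0-fold lower number from compound 2 to compound 4 (0.78 log units; beyond the scatter). For compound 4 the estimated value is 4.5 ug/mL, with an expected range from 1.8 ug/mL to 12 ug/mL.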

Compound 4, half-maximal inhibitory concentration: 3.47 ug/mL
For compound 4 the middle estimate is 1.3-fold (0.11 log units) above the measured one; low and high end bracket the measured number.
By their numbers in this assay, from the lowest: compounds 3, 4 and 1 (each within the scatter of the next); then compound 2.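

The missing step is now readable: hydrogen in place of the chloro of compound 1 gives a 1.1-fold lower number from compound 1 to compound 4 (0.04 log units; within the scatter), so in this assay that chloro shows no effect beyond the scatter, and only the 2,4-dichlorophenyl of compound 2 stands apart. Removing both chloro groups gives a 7.8-fold lower number from compound 2 to compound 4 (0.89 log units; beyond the scatter), and phenyl in place of isopropyl on the carbonyl carbon gives no change at the digits printed from compound 3 to compound 4 (within the scatter), so phenyl, 4-chlorophenyl and isopropyl cannot be told apart here, with compound 2 the one exception among the four compounds. No measurement available here accounts for the higher number of compound 2, so the data record the difference without explaining it.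

The compounds shown leave open whether a phenyl carrying only the chloro that compound 2 has beyond compound 1 would give a number as high as compound 2, or whether the higher number needs both chloro groups together. They also leave open how far this flat stretch extends, for instance to an amine or a carboxylic acid on the phenyl, or to a longer chain in place of isopropyl.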